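Swapping piperidin-1-yl for 4-(4-methylpiperazin-1-yl)butyl

This account rests on a few compounds, and the source may have more. Where it says the series, first, only, none or still open, it means among the compounds named here.

In a functional assay on HCT-116 cells (Homo sapiens) for cytotoxicity, read by MTT assay, with a stated time of 72 h (on this read-out higher numbers stand for weaker inhibition and lower numbers for stronger inhibition), compound 2 `O=C1c2c[n+]([O-])c3ccccc3c2C(=O)c2c1c1ccccc1n2CCN1CCCCC1` gives 780 nM, and compound 1 `CCCN1CCN(CCCCn2c3c(c4ccccc42)C(=O)c2c[n+]([O-])c4ccccc4c2C3=O)CC1` gives 790 nM, so the two stand level within the scatter. The next compound to be tested is compound 3 `CN1CCN(CCCCCCn2c3c(c4ccccc42)C(=O)c2c[n+]([O-])c4ccccc4c2C3=O)CC1`, and its difference from compound 2 is 4-(4-methylpiperazin-1-yl)butyl in place of piperidin-1-yl on a saturated chain carbon, two bonds along the chain from an aromatic nitrogen. It carries 4-(4-methylpiperazin-1-yl)butyl in place of piperidin-1-yl on a saturated chain carbon, two bonds along the chain from an aromatic nitrogen. Among the compounds with values here, only one measured step bears on this change: a 1.0-fold lower number from compound 1 to compound 2 (0.01 log units; within the scatter). That step exchanged 2-(4-propylpiperazin-1-yl)ethyl for piperidin-1-yl at the same place, and it stayed within the scatter. On this single pair, no change beyond the scatter is expected, in either direction. The expected step is a 1.0-fold higher number from compound 2 to compound 3 (0.01 log units; within the scatter). For compound 3 the estimated value is 800 nM, with an expected range of 350 nM to 1800 nM.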

Compound 3, half-maximal inhibitory concentration: 2900 nM
Beside the measured number, compound 3's estimate is 3.6-fold (0.56 log units) below it; the measured number lies above the stated range.
By their numbers in this assay, from the lowest: compounds 2 and 1 (each within the scatter of the next); then compound 3.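

In this assay the group at this place proved not to be indifferent: a 3.7-fold higher number from compound 2 to compound 3 (0.57 log units; beyond the scatter), whereas the earlier exchange there had stayed within the scatter. Carrying a piperazine ring does not by itself set the number, as compound 1 also carries one and stands level with compound 2, yet a 3.7-fold higher number from compound 1 to compound 3 (0.56 log units; beyond the scatter), with 2-(4-methylpiperazin-1-yl)ethyl in place of 4-propylpiperazin-1-yl. Nothing shown here gives a reason for this rise.

Going by these compounds, the step to compound 3 alters the chain and the alkyl group on the piperazine together, and it remains open which of the two carries it. Also open, on these data alone, is how a morpholine or a simple dimethylamine at the end of the chain, or an even longer chain, would read.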